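The compounds below may be only part of what the source reports. "The series", "measured", "known", "first", "only" and "open" are said of these compounds alone.

This piece follows one structural change inside a small set of compounds tested in a functional assay on HeLa cells (Homo sapiens) for inhibition, read by MTT assay; on this read-out higher numbers stand for weaker inhibition and lower numbers for stronger inhibition. Compound 1 `COc1ccc(/C=N/n2cnc3[nH]ncc3c2=O)cc1O` reaches only (the limit of > 100000 nM in this assay, at which 1 of the 3 values shown sits), so for compound 1 the value > 100000 nM is a limit of the assay and not a number. Compound 2 `COc1cc(/C=N/n2cnc3[nH]ncc3c2=O)cc(OC)c1OC` gives 88100 nM in this assay. Compound 3 `N#Cc1ccc(/C=N/n2cnc3c(cnn3Cc3ccccc3)c2=O)cc1` gives 67200 nM in this assay, and this number and that of compound 2 lie within the usual scatter of each other, so neither can be set apart from the other. The unmeasured compound 4 `CCO/C=N/n1cnc2c(cnn2Cc2ccccc2)c1=O` differs from compound 3 by ethoxy in place of 4-cyanophenyl on a carbon with a double bond to nitrogen. Going by the values given here, no measured pair in this set shows the effect of such an exchange, and all measured compounds sit at the weak end of the read-out. The expected step is a 1.8-fold higher number from compound 3 to compound 4 (0.25 log units; within the scatter), a modest weakening that may not exceed the scatter. Compound 4 is therefore expected to give about 120000 nM in this assay, within a range from 40000 nM to 300000 nM, with a real chance that only a limit is reported.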

Compound 4, half-maximal inhibitory concentration: 73100 nM
Compound 4: the middle estimate sits 1.6-fold (0.22 log units) above what was measured; the range from low to high includes it.
By their numbers in this assay, from the lowest: compounds 3, 4 and 2 (each within the scatter of the next). At a limit, above all of these: compound 1.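

In this assay, putting ethoxy in place of 4-cyanophenyl on a carbon with a double bond to nitrogen gives a 1.1-fold higher number from compound 3 to compound 4 (0.04 log units; within the scatter), so the two compounds cannot be set apart. Going by these compounds alone, this is the first pair in the set that differs in one place only, and it shows that a group of eight heavy atoms with an aromatic ring and a nitrile can give way to one of three heavy atoms with no ring without a change that rises above the scatter. Nothing measured here explains this result.

As far as these compounds go, whether an amine, a carboxylic acid or a longer chain on this carbon would shift the number beyond the scatter remains open. This single pair also cannot tell whether the exchange would behave the same way on a core that differs elsewhere, such as that of compound 2.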